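A few compounds are considered here, and "the series" means these few. Any claim that something is new, unique, unknown or untested is made for them only; others in the source may bear on it.

Among the compounds with values here, compound 1 `CCCSc1nc(N)c2nc(O)n(Cc3ccccc3)c2n1` is one of two compounds measured in a functional assay (spleen, spleen) for activation, with Mus musculus as the target (a lower number here means that less compound is needed, a higher number that more compound is needed for the effect), and in that assay compound 1 gives 0.01 uM, the lowest of the two numbers. The other measured compound, compound 2 `Nc1ncnc2c1nc(O)n2Cc1cccc2ccccc12`, gives 10 uM in this assay, a far higher number than compound 1 and beyond the usual scatter; the two differ at more than one place, so the pair shows only what its two values show. The unmeasured compound 3 `CCc1nc(N)c2nc(O)n(Cc3ccccc3)c2n1` is reached from compound 1 by a single change: ethyl in place of propylsulfanyl on an aromatic carbon. Within the data shown here, no step between measured compounds tells how this assay responds to such a change. The account expects compound 3 to need somewhat more compound than compound 1, since the propylsulfanyl group is part of the compound that gives 0.01 uM. The estimated step of a 5.0-fold higher number from compound 1 to compound 3 (0.70 log units; beyond the scatter) is modest but likely beyond the scatter. Compound 3 is thus estimated at 0.05 uM, with a range from 0.01 uM to 0.3 uM.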

Compound 3, minimum effective concentration: 1 uM
Beside the measured number, compound 3's estimate is 20-fold (1.30 log units) below it; measured number outside the range, above it.
By their numbers in this assay, from the lowest: compound 1; then compound 3; then compound 2.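

Within the data shown here, the step is the first reading at this position, the aromatic carbon between two ring nitrogen atoms: in this assay, ethyl in place of propylsulfanyl gives (a 100-fold higher number from compound 1 to compound 3 (2.00 log units; beyond the scatter)), a large step. With the rest of the core of compound 1 unchanged, this one group alone moves the number far beyond the usual scatter, so the assay responds strongly to what stands at this place. Nothing available here bears on why this change has so large an effect.

The compounds shown leave open whether the step goes with the sulfur or with the length of the chain, a question that a propyl chain or an ethylsulfanyl group at this place would address. As far as these compounds go, how an amine or a longer chain such as hexylsulfanyl would read in this assay also remains open.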